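The compounds below may be only part of what the source reports. "The series", "measured", "known", "first", "only" and "open" are said of these compounds alone.

Of the compounds shown here, two have been measured so far in a functional assay on MIA PaCa-2 cells (Homo sapiens) for inhibition, read by MTT assay, with a stated time of 72 h, tested at 50 uM; a higher number here means more inhibition of growth at the concentration tested, a lower number less inhibition of growth. Compound 1, `C=CCc1ccc(OCc2cn(-c3ccccc3Cl)nn2)c(O)c1`, gives 57.7% in this assay. Compound 2, `C=CCc1cc(O)c(O)c(CN2CCC(Cc3ccccc3)CC2)c1`, which shares the allyl phenol part but carries a different arrangement of groups, gives 90.9% in this assay. Compound 1 therefore stands at the lower of the two numbers, and the gap to compound 2 is beyond the usual scatter.

Compound 3, `C=CCc1ccc(OCc2cn(-c3ccc(OC)cc3)nn2)c(O)c1`, has not yet been measured. It differs from compound 1 in one place: 4-methoxyphenyl in place of 2-chlorophenyl on an aromatic nitrogen. Going by the values given here, no measured pair shows the effect of swapping one aromatic group for another on that ring nitrogen, so there is no direct guide. The expected step from compound 1 to compound 3 is estimated as small, a number 2.7 percentage points lower from compound 1 to compound 3 (within the scatter), and may fall within the scatter. For compound 3 the estimated result in this assay is 55%, with a range from 35% to 75%.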

Compound 3, percent growth inhibition at one concentration: 88.2%
Beside the measured number, compound 3's estimate is 33.2 percentage points below it; the measured number lies above the stated range.
By their numbers in this assay, from the lowest: compound 1; then compounds 3 and 2 (each within the scatter of the next).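

In this assay the group on the aromatic nitrogen of the ring with three nitrogens proves able to move the result: 4-methoxyphenyl in place of 2-chlorophenyl gives a number 30.5 percentage points higher from compound 1 to compound 3 (beyond the scatter) with the rest of the molecule unchanged. Going by these compounds alone, this is the first measured sign that this position is sensitive to which aromatic group it carries, a point the two earlier compounds could not show, as they differ in more than one place. The data offer no measured explanation for this step.

The swap removes the chlorine, adds the methoxy group and changes the substituent's place on the phenyl ring all at once, so the step cannot be assigned to any one of these changes. A plain phenyl, 4-chlorophenyl or 2-methoxyphenyl at this position would help to separate them, while an aminophenyl would test a different kind of substituent.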